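The compounds below may be only part of what the source reports. "The series", "measured", "known", "first", "only" and "open" are said of these compounds alone.

Measured compounds:
compound 1 `CC(C)(C)n1cc2c(n1)C(=O)CC1(CCN(C(=O)c3cc(-c4ccccc4)nc4ccccc34)CC1)O2` — > 10000 nM
compound 2 `CC(C)(C)n1cc2c(n1)C(=O)CC1(CCN(C(=O)c3cc(-c4ccc(F)cc4)nc4ccccc34)CC1)O2` — > 10000 nM
compound 3 `CC(C)(C)n1cc2c(n1)C(=O)CC1(CCN(C(=O)c3cc(-c4ccc(Br)cc4)nc4ccccc34)CC1)O2` — > 10000 nM

In a functional assay on MDA-MB-231 cells (Homo sapiens) for inhibition, read by MTT assay, with a stated time of 72 h (a higher number here means a weaker inhibitor, a lower number a stronger inhibitor), compound 1 gives > 10000 nM, which is a limit of the assay and not a number. Compound 2 also sits at this limit, with > 10000 nM. Compound 3 likewise returns > 10000 nM, again a limit. Because of the limit of > 10000 nM in this assay, at which 3 of the 3 values shown sit, none of the three steps among them can be read: a step that the two limits leave unreadable from compound 1 to compound 2, a step that the two limits leave unreadable from compound 1 to compound 3 and a step that the two limits leave unreadable from compound 2 to compound 3 are all of unreadable size.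

Compound 4 `COc1ccc(-c2cc(C(=O)N3CCC4(CC3)CC(=O)c3nn(C(C)(C)C)cc3O4)c3ccccc3n2)cc1` is the next member; it differs from compound 1 by methoxy in place of hydrogen on an aromatic carbon. For the measured compounds named here, the steps that bear on it are the fluoro and bromo substitutions on an aromatic carbon in compound 2 and compound 3, both of unknown size since every value stands at the limit. Going by the values given here, no measured step gives direction, so no step beyond the scatter is expected from compound 1 to compound 4 in this assay; the estimated step is a step that the limit leaves unreadable from compound 1 to compound 4. Compound 4 is accordingly expected to give about 15000 nM, within 4000 nM to 60000 nM, most likely reported as a limit.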

Compound 4, half-maximal inhibitory concentration: > 10000 nM
Compound 4: a limit, no number (the forecaster's own chance of this, stated with the estimate: 85%); the middle value lies beyond the limit too.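

In this assay compound 4 gives > 10000 nM, a limit and not a number, so no step among compound 1, compound 2, compound 3 and compound 4 can be read: the limit of > 10000 nM in this assay, at which 4 of the 4 values shown sit.

The compounds shown leave open whether any change on this phenyl ring gives a readable value in this assay.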